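Replacing the amino group with two chlorines

This account rests on a few compounds, and the source may have more. Where it says the series, first, only, none or still open, it means among the compounds named here.

Measured so far in a functional assay (aorta) for inhibition, with Rattus norvegicus as the target (a lower number here means a stronger inhibitor, a higher number a weaker inhibitor), are three compounds:
Compound 1 `Cc1nsc(-c2ccc(N3CCN(c4cccc(C#N)c4)CC3)nn2)n1` gives 3 nM
Compound 2 `Cc1nsc(-c2ccc(N3CCN(c4cccc([N+](=O)[O-])c4)CC3)nn2)n1` gives 3 nM
Compound 3 `Cc1nsc(-c2ccc(N3CCN(c4cccc(N)c4)CC3)nn2)n1` gives > 100 nM

For compound 3 the entry > 100 nM is a limit of the assay and not a number. Within the data shown here, of the three, it is the weakest inhibitor, and the only one without a measured value. The other two are not told apart, as the data show no change at the digits printed from compound 1 to compound 2 (within the scatter) and nothing more. Two large steps lead to the amino compound: an at least 33-fold higher number from compound 1 to compound 3 (1.52 log units; beyond the scatter) and an at least 33-fold higher number from compound 2 to compound 3 (1.52 log units; beyond the scatter) are the measured changes that bear on what follows.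

Compound 4 `Cc1nsc(-c2ccc(N3CCN(c4cc(Cl)cc(Cl)c4)CC3)nn2)n1` carries 3,5-dichlorophenyl in place of 3-aminophenyl on an amine nitrogen in a ring. Like compound 1 at 3 nM and compound 2 at 3 nM, it has no amino group, so a large move towards a lower number is expected. Among the measured compounds shown here, no measured compound carries chlorine, however, so the full size of those two steps may not be recovered. The step expected here is an at least 10-fold lower number from compound 3 to compound 4 (1.00 log units; beyond the scatter) and it remains an estimate. For compound 4 the estimated value is 10 nM (range 2 nM to 60 nM).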

Compound 4, half-maximal inhibitory concentration: < 0.1 nM
Compound 4 gave a limit, no number; the forecaster's own chance of this, stated with the estimate: 12%; middle value at least 100-fold (2.00 log units) from the limit.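

In this assay compound 4 gives < 0.1 nM, which is a limit of the assay and not a number. The earlier compounds shown here showed only that 3-aminophenyl on an amine nitrogen in a ring stood apart from 3-cyanophenyl and 3-nitrophenyl, which could not be told apart, whereas 3,5-dichlorophenyl at this position now separates from both of them, with an at least 30-fold lower number from compound 1 to compound 4 (1.47 log units; beyond the scatter) and an at least 30-fold lower number from compound 2 to compound 4 (1.47 log units; beyond the scatter), so this change does more than return to the level of those two. Set against 3-aminophenyl, the change gives an at least 1000-fold lower number from compound 3 to compound 4 (3.00 log units; beyond the scatter), and as both ends of that step are limits, it fixes only a bound on its size: the limit of < 0.1 nM in this assay, at which 1 of the 4 values shown sits.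

As far as these compounds go, the change from compound 3 to compound 4 removes the amino group and adds two chlorines in one move, so it remains open whether 3-chlorophenyl, unsubstituted phenyl or 3,5-dimethylphenyl would stand with compound 4 or with compound 1 and compound 2. From the compounds shown here alone, the actual value of compound 4 also remains open, and with it the full size of all three steps.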